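The source may report more compounds than this note shows. Statements on the series, on what has been measured and on what is new or still open speak of the compounds shown alone.

Compound 2 `O=C(/C=C/c1cc2ccccc2[nH]c1=O)c1ccc(O)cc1` holds the only plain number shown; in an ADME assay on TK-10 cells (Homo sapiens) for cytotoxicity, read by sulforhodamine B assay, with a stated time of 24 h (a higher number here means that more compound is tolerated, a lower number that less compound is tolerated), compound 2 gives 34600 nM. Compound 1 `COc1ccc(C(=O)/C=C/c2cc3ccccc3[nH]c2=O)cc1` is reported in this assay only as a limit, > 100000 nM. One of the two values therefore sits at a limit (the limit of > 100000 nM in this assay, at which 1 of the 2 values shown sits). Going by the values given here, the sole measured step, an at least 2.8-fold lower number from compound 1 to compound 2 (0.46 log units; beyond the scatter), removed the hydroxy hydrogen by methyl capping. Compound 3 `O=C(/C=C/c1cc2ccccc2[nH]c1=O)c1ccc(Cl)cc1` differs from compound 2 by chloro in place of hydroxy on an aromatic carbon. Since the measured step of an at least 2.8-fold lower number from compound 1 to compound 2 (0.46 log units; beyond the scatter) also removed the hydroxy, a rise of comparable size is expected, a 1.9-fold higher number from compound 2 to compound 3 (0.27 log units; within the scatter). Compound 3 is thus estimated at 65000 nM, within 25000 nM to 160000 nM.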

Compound 3, concentration lethal to 50% of the cells: 75800 nM
Estimate against measurement, compound 3: 1.2-fold (0.07 log units) below; the measured number falls inside the stated range.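

In this assay, a second replacement of the hydroxy on this carbon, para to a large group, also raises the number: a 2.2-fold higher number from compound 2 to compound 3 (0.34 log units; beyond the scatter), so among these three compounds, compound 2 with its hydroxy has the lowest number. Chloro and methoxy cannot be put in order, since the step reads an at least 1.3-fold lower number from compound 1 to compound 3 (0.12 log units; that floor lies within the scatter). Compound 1 is reported only as a limit: the limit of > 100000 nM in this assay, at which 1 of the 3 values shown sits.

Going by these compounds, whether an amine or a carboxylic acid in place of the hydroxy would keep the number of compound 2 or raise it remains open.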